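Three amide variants on a shared core, and a fourth

A few compounds are considered here, and "the series" means these few. Any claim that something is new, unique, unknown or untested is made for them only; others in the source may bear on it.

The three measured compounds share one core and differ only in the aromatic group attached to the carbonyl carbon of an amide. Compound 1 `O=C(Nc1cccc(-c2oc3cc(-c4ccc(F)cc4)ccc3c(=O)c2O)c1)c1ccccc1F` gives 4410 nM in a functional assay on A549 cells (Homo sapiens) for antiproliferative activity, read by CCK-8 assay, with a stated time of 72 h; on this read-out higher numbers stand for weaker inhibition and lower numbers for stronger inhibition. Compound 2 `Cc1cc(C(=O)Nc2cccc(-c3oc4cc(-c5ccc(F)cc5)ccc4c(=O)c3O)c2)ccc1F` gives 11500 nM in this assay, and compound 3 `Cc1cc(C)cc(C(=O)Nc2cccc(-c3oc4cc(-c5ccc(F)cc5)ccc4c(=O)c3O)c2)c1` gives 3740 nM. Compound 3 has the lowest number of the three, but its gap to compound 1 is within the scatter, so the two cannot be ordered; only its gap to compound 2 is beyond the scatter, as the step of a 3.1-fold lower number from compound 2 to compound 3 (0.49 log units; beyond the scatter) shows. The step of a 1.2-fold lower number from compound 1 to compound 3 (0.07 log units; within the scatter) is within the scatter, and a 2.6-fold higher number from compound 1 to compound 2 (0.42 log units; beyond the scatter) is modest.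

Compound 4 `CCCc1ccc(C(=O)Nc2cccc(-c3oc4cc(-c5ccc(F)cc5)ccc4c(=O)c3O)c2)cc1` carries the change (4-propylphenyl in place of 3,5-dimethylphenyl on a carbonyl carbon). Every measured step swaps this same aromatic group, and none moved the number by more than a modest amount. The step from compound 3 to compound 4 is therefore expected to be small, a 1.2-fold higher number from compound 3 to compound 4 (0.08 log units; within the scatter), with no clear direction. Compound 4 is estimated at 4500 nM, within a range from 1500 nM to 13000 nM.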

Compound 4, half-maximal inhibitory concentration: 47600 nM
Beside the measured number, compound 4's estimate is 11-fold (1.02 log units) below it; measured number above the stated range.
By their numbers in this assay, from the lowest: compounds 3 and 1 (each within the scatter of the next); then compound 2; then compound 4.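

This position on the carbonyl carbon is less forgiving than the first three compounds suggested: in this assay, replacing 3,5-dimethylphenyl with 4-propylphenyl weakens inhibition strongly (a 13-fold higher number from compound 3 to compound 4 (1.10 log units; beyond the scatter)), although the entering group has only one more carbon. Compound 4 also gives higher numbers than the other two compounds (an 11-fold higher number from compound 1 to compound 4 (1.03 log units; beyond the scatter); a 4.1-fold higher number from compound 2 to compound 4 (0.62 log units; beyond the scatter)), making it the weakest of the four. Both groups have one six-membered aromatic ring of carbon only and no hydrogen-bond donors or acceptors, so these counted features do not separate them.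

The data available here give no explanation for this loss of activity. As far as these compounds go, it remains open whether the loss follows the length of the chain, which 4-methylphenyl, 4-ethylphenyl or 4-butylphenyl could help to show.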